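Working notes: replacing the aryl group of compound 2

A few compounds are considered here, and "the series" means these few. Any claim that something is new, unique, unknown or untested is made for them only; others in the source may bear on it.

Measured in a functional assay on U-251 cells (Homo sapiens) for inhibition, read by sulforhodamine B assay, with a stated time of 48 h; a higher number here means a weaker inhibitor of growth, a lower number a stronger inhibitor of growth:
- compound 1 `O=C(Cc1csc2nc(-c3ccc(Br)cc3)cn12)N/N=C/c1ccccc1`: 12900 nM
- compound 2 `COc1cccc(OC)c1/C=N/NC(=O)Cc1csc2nc(-c3ccc(Br)cc3)cn12`: 13800 nM

Compound 2, at 13800 nM, stands within the scatter of compound 1, at 12900 nM. With only these two numbers, the series gives little to rank against.

The next compound is compound 3 `O=C(Cc1csc2nc(-c3ccc(Br)cc3)cn12)N/N=C/c1ccc(Cl)cc1Cl`, not yet measured. In it, 2,4-dichlorophenyl replaces 2,6-dimethoxyphenyl on a carbon with a double bond to nitrogen (2,4-dichlorophenyl in place of 2,6-dimethoxyphenyl on a carbon with a double bond to nitrogen).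

Among the compounds with values here, only one measured step bears on this place: a 1.1-fold higher number from compound 1 to compound 2 (0.03 log units; within the scatter). That step stays within the scatter, so the two aryl groups measured so far do not separate in this assay. Within the data shown here, no compound measured so far carries a chlorine-bearing aryl group, so this single step is thin support and the range is kept wide. No step beyond the scatter is expected. The expected step is a 1.3-fold lower number from compound 2 to compound 3 (0.10 log units; within the scatter). For compound 3 the estimated value is 11000 nM, with an expected range of 5000 nM to 25000 nM.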

Compound 3, concentration for 50% growth inhibition: 20400 nM
For compound 3 the middle estimate is 1.9-fold (0.27 log units) below the measured one; measured number inside the range.
By their numbers in this assay, from the lowest: compounds 1, 2 and 3 (each within the scatter of the next).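

In this assay the first aryl group carrying chlorine does not separate from the other two, with a 1.5-fold higher number from compound 2 to compound 3 (0.17 log units; within the scatter) and a 1.6-fold higher number from compound 1 to compound 3 (0.20 log units; within the scatter) as its steps. On a carbon with a double bond to nitrogen, phenyl, 2,6-dimethoxyphenyl and 2,4-dichlorophenyl therefore all lie within the scatter of one another, even though 2,6-dimethoxyphenyl has 2 hydrogen-bond acceptors and 2,4-dichlorophenyl has 0, so this count does not track a readable difference across these three compounds. No measurement at hand accounts for this flat result or speaks to what any of these groups does in the cells.

At this place the compounds shown hold only phenyl, plain or bearing methoxy or chlorine groups, so it remains open whether a ring carrying a dimethylamino group or a carboxylic acid, or a pyridine ring in place of phenyl, would give a step beyond the scatter. The rest of the molecule is the same in all three compounds, which also leaves open whether a change elsewhere on the shared core would move the number.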